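Swapping a chain for a hydroxy group at a growth-inhibition limit

A few compounds are considered here, and "the series" means these few. Any claim that something is new, unique, unknown or untested is made for them only; others in the source may bear on it.

Compound 1 `CCCCOC[C@H]1O[C@@H](CCC)[C@H](O)[C@@H](OCCCC)C1OCCCC` gives > 50000 nM (a limit)
Compound 2 `CCCC[C@@H]1O[C@H](COCc2ccccc2)[C@@H](OCc2ccccc2)[C@H](OCc2ccccc2)[C@H]1O` gives > 50000 nM (a limit)

Both entries come from a functional assay on HeLa cells (Homo sapiens) for antiproliferative activity, read by sulforhodamine B assay (a lower number here means a stronger inhibitor of growth, a higher number a weaker inhibitor of growth), and neither is an exact number. Compound 2 stands at > 50000 nM in this assay, which is a limit and not a number. Among the measured compounds shown here, the same holds for the whole set so far, with the limit of > 50000 nM in this assay, at which 2 of the 2 values shown sit, as the only reading. For the measured compounds named here, no measured step therefore shows how much a change in structure can move growth inhibition.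

Compound 3 `OC[C@@H]1O[C@H](COCc2ccccc2)[C@@H](OCc2ccccc2)[C@H](OCc2ccccc2)[C@H]1O` changes compound 2 in one place, with hydroxy in place of propyl on a saturated chain carbon bound to a saturated ring carbon. Cut one bond further out, the same difference reads butyl to hydroxymethyl.

Going by the values given here, with no measured step as a guide, only a modest move toward stronger growth inhibition is expected in this assay, and none beyond the scatter is quite possible. The estimated step of an at least 1.4-fold lower number from compound 2 to compound 3 (0.15 log units; that floor lies within the scatter) is accordingly small, and a further limit is a likely outcome. For compound 3 the estimated value is 35000 nM, with an expected range from 12000 nM to 50000 nM.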

Compound 3, concentration for 50% growth inhibition: 25800 nM
Compound 3: middle estimate off by 1.4-fold (0.13 log units), on the high side, within the range that was stated.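

Compound 3 is the only compound shown that gives an exact number rather than a limit in this assay, so this place, a saturated chain carbon bound to a saturated ring carbon, now has one reading that sits on the scale. Putting hydroxy in place of propyl there gives an at least 1.9-fold lower number from compound 2 to compound 3 (0.28 log units; that floor lies within the scatter); this is only a floor, since one end of the step is a limit, so the true step may be larger, but the floor alone does not show a change beyond the scatter. The size of this change therefore stays open at one end, and most of the set still gives no exact number: the limit of > 50000 nM in this assay, at which 2 of the 3 values shown sit.

The compounds shown leave open how an amine or a carboxylic acid would read at this same place, and whether a longer chain than propyl would also give only a limit. They also leave open whether plain hydrogen at this place would read like hydroxy, which would separate the loss of propyl from the arrival of hydroxy.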